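The compounds below may be only part of what the source reports. "The series", "measured", "known", "first", "only" and "open" are said of these compounds alone.

Of the compounds shown here, three with a shared core have been tested in a functional assay on HEK293 cells for agonist activity at D(4) dopamine receptor (Homo sapiens), read by FLIPR; a higher number here means a larger maximal response, a lower number a smaller maximal response. Compound 1 `O=C(CN1CCC(c2cccc[n+]2[O-])CC1)Nc1ccc(F)cc1F` gives 74% in this assay, the top of the three numbers. Compound 2 `Cc1cccc(Cl)c1NC(=O)CN1CCC(c2ccccn2)CC1` gives 70% in this assay, a number that lies within the usual scatter of the value of compound 1, so the two cannot be told apart. Compound 3 `C=Cc1cccc(C(=O)NCN2CCC(c3cccc[n+]3[O-])CC2)c1` gives 63% in this assay, which sits beyond the scatter below compound 1.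

Compound 4 `O=C(CN1CCC(c2cccc[n+]2[O-])CC1)Nc1cccc(Cl)c1` has not yet been measured. It differs from compound 1 in one place: 3-chlorophenyl in place of 2,4-difluorophenyl on an amide-type nitrogen. Among the compounds with values here, no measured pair shows what such a change does here. Because compound 2 gives 70% with a different ring on the same kind of nitrogen, a step from compound 1 to compound 4 that stays within the scatter is expected, a number 6 percentage points lower from compound 1 to compound 4 (within the scatter). Compound 4 is therefore estimated at 68%, with a likely range from 54% to 80%.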

Compound 4, largest response reached (reported as efficacy), in percent of the reference or control that the assay uses: 76%
Compound 4: the middle estimate sits 8 percentage points below what was measured, and the stated range covers the measured number.
By their numbers in this assay, from the lowest: compounds 3, 2, 1 and 4 (each within the scatter of the next, the first and the last beyond it).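

In this assay, 3-chlorophenyl in place of 2,4-difluorophenyl on an amide-type nitrogen gives a number 2 percentage points higher from compound 1 to compound 4 (within the scatter), so compound 1 and compound 4 cannot be told apart. This first one-place comparison shows that this position accepts a ring with one chlorine as well as a ring with two fluorines, with no measurable change in maximal response. No available measurement offers an explanation for this result. As far as these compounds go, it remains open whether a non-aromatic ring such as cyclohexyl, or a phenyl ring carrying a methoxy group or a nitrile, would keep this response.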